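This account rests on a few compounds, and the source may have more. Where it says the series, first, only, none or still open, it means among the compounds named here.

Measured so far in an ADME assay on BaF3 cells (Mus musculus) for cytotoxicity; a lower number here means that less compound is needed, a higher number that more compound is needed for the effect:

Compound 1 `NC(=O)c1ccc(-c2cc(Nc3ccc(OC(F)(F)F)cc3)ncn2)cc1`: in this assay compound 1 gives > 10000 nM, which is a limit of the assay and not a number.
Compound 2 `FC(F)(F)Oc1ccc(Nc2cc(-c3cn[nH]c3)ncn2)cc1`: in this assay compound 2 gives > 10000 nM, again only a limit.
Compound 3 `FC(F)(F)Oc1ccc(Nc2cc(-c3ccncc3)ncn2)cc1`: in this assay compound 3 gives > 10000 nM, also a limit.

Compound 3 therefore stands at the limit of this assay, and the two other values sit at the same place (the limit of > 10000 nM in this assay, at which 3 of the 3 values shown sit). On these data alone, none of the three measured steps can be read: a step that the two limits leave unreadable from compound 1 to compound 2, a step that the two limits leave unreadable from compound 1 to compound 3 and a step that the two limits leave unreadable from compound 2 to compound 3 all lie between two limits, so their size and direction are unknown.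

Compound 4 `FC(F)(F)Oc1ccc(Nc2cc(-c3ccc4[nH]ccc4c3)ncn2)cc1` is the next compound; it differs from compound 3 by 1H-indol-5-yl in place of pyridin-4-yl on an aromatic carbon. For the measured compounds named here, the steps that bear on this change are those that exchange the same group on the shared core, from compound 1 to compound 2, from compound 1 to compound 3 and from compound 2 to compound 3, and all three are unreadable. The data thus give no direction for this assay. The working expectation is that compound 4 also sits at the limit, with an estimated value of 10000 nM and a range from 3000 nM to 30000 nM. The step from compound 3 to compound 4 is accordingly expected to be a number no higher from compound 3 to compound 4 (the limit leaves the size open), none beyond the scatter.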

Compound 4, half-maximal effective concentration: > 10000 nM
Compound 4: a limit, no number; the forecaster's own chance of this, stated with the estimate: 75%; the middle value sits exactly at the limit.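

In this assay compound 4 gives > 10000 nM, which is a limit and not a number, so its steps from compound 1, compound 2 and compound 3 cannot be read. The compounds shown leave open whether any group at this place on the shared core gives a readable value, as all stand together: the limit of > 10000 nM in this assay, at which 4 of the 4 values shown sit.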